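The source may report more compounds than this note shows. Statements on the series, on what has been measured and on what is new or still open speak of the compounds shown alone.

Compound 3 `COc1ccc(C2C(C#N)=C(N)OC(c3c[nH]c4ccccc34)=C2C#N)cc1OC` is the starting point. In a functional assay, tested at 100 ug/mL (on this read-out higher numbers stand for a stronger effect at the one concentration tested and lower numbers for a weaker effect), compound 3 gives 19.1%, the lower of the two numbers in hand; its nearest neighbour is compound 1 `COc1cc(Br)c(C2C(C#N)=C(N)OC(c3c[nH]c4ccccc34)=C2C#N)cc1OC`, which gives 20.5%, and the step of a number 1.4 percentage points lower from compound 1 to compound 3 (within the scatter) lies within the scatter. Compound 2 `N#CC1=C(N)OC(c2c[nH]c3ccccc23)=C(C#N)C1c1ccc2ccccc2c1` is reported as "not active" (no number reported), with no number.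

Compound 4 `COc1ccc(C2C(C#N)=C(N)OC(c3c[nH]c4ccccc34)=C2C#N)cc1` differs from compound 3 by hydrogen in place of methoxy on an aromatic carbon. Within the data shown here, no measured step removes a methoxy group, so the only guide is the unrelated, within-scatter step from compound 1 to compound 3, together with the inactivity of compound 2, which carries no methoxy at all. A modest drop is therefore expected, a number 5.1 percentage points lower from compound 3 to compound 4 (within the scatter), likely still within the scatter. Compound 4 is estimated at 14%, ranging from 2% to 26%.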

Compound 4, a percentage reported as activity, at one concentration (the size of the read-out at that concentration, not a potency): 20%
Compound 4: middle estimate off by 6 percentage points, on the low side, within the range that was stated.
By their numbers in this assay, from the lowest: compounds 3, 4 and 1 (each within the scatter of the next).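

In this assay, among these compounds, the step of a number 0.9 percentage points higher from compound 3 to compound 4 (within the scatter) is the first measured change at this position. Going from 3,4-dimethoxyphenyl to 4-methoxyphenyl leaves the read-out within the scatter, so this methoxy group can be replaced by hydrogen without a measurable change in this assay. No evidence is available on what lies behind this result. Still open, on these data alone, is whether another group at this position, such as an amine or a carboxylic acid, would move the read-out beyond the scatter, and whether the remaining methoxy group can also be removed.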